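Permeability notes: methoxypyridinyl to methoxyphenyl on the acylurea

The source may hold more compounds than are shown below. What is called first, only, known or untested is meant among the compounds shown, and "the series" means these compounds.

Of the compounds shown here, three have numbers so far. Compound 1 `COc1ccccc1C(=O)NC(=O)Nc1ccc(-c2ccccc2)c(C(C)C)c1` gives 1.2 10^-6 cm/s in an ADME assay on LLC-PK1 cells (Sus scrofa) for permeability; on this read-out lower numbers stand for lower permeability and higher numbers for higher permeability. Compound 2 `COc1ccccc1C(=O)NC(=O)Nc1ccc(-c2ccccn2)c(C(F)(F)F)c1` gives 7.4 10^-6 cm/s in this assay. Compound 3 `COc1ccncc1C(=O)NC(=O)Nc1ccc(-c2ccccc2)c(C(F)(F)F)c1` gives 2.3 10^-6 cm/s in this assay and so stands second highest of the three numbers; its nearest neighbour is compound 1, a gap that lies within the scatter, and its furthest is compound 2, a gap that lies beyond the scatter. Within the data shown here, none of these three pairs differ in only one place, so no single step is computed among them; of each pair only the two numbers themselves can be said.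

Compound 4 `COc1ccccc1C(=O)NC(=O)Nc1ccc(-c2ccccc2)c(C(F)(F)F)c1` is not yet measured in this assay. It differs from compound 3 in one place: 2-methoxyphenyl in place of 4-methoxypyridin-3-yl on a carbonyl carbon. The change leaves the rest of the shared core untouched.

For compound 4 the number in this assay is expected to sit near that of compound 3, with at most a small rise, because compound 3 already gives 2.3 10^-6 cm/s and the expected step of a 1.5-fold higher number from compound 3 to compound 4 (0.18 log units; within the scatter) is of a size that the scatter could cover. The estimate for compound 4 is 3.5 10^-6 cm/s, with a range from 1.5 10^-6 cm/s to 9 10^-6 cm/s.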

Compound 4, apparent permeability in the LLC-PK1 assay: < 1 10^-6 cm/s
Compound 4: only a limit was reported; the forecaster's own chance of this, stated with the estimate: 5%; middle value at least 3.5-fold (0.54 log units) away from the limit.
By their numbers in the LLC-PK1 assay, from the lowest: compounds 1 and 3 (each within the scatter of the next); then compound 2. At a limit, below all of these: compound 4.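

With the change on the carbonyl carbon, the number in the LLC-PK1 assay falls (an at least 2.3-fold lower number from compound 3 to compound 4 (0.36 log units; beyond the scatter)), and phenyl in place of pyridin-2-yl on an aromatic carbon gives a lower number as well (an at least 7.4-fold lower number from compound 2 to compound 4 (0.86 log units; beyond the scatter)), so these two steps into compound 4 are floors beyond the scatter, while the step for trifluoromethyl in place of isopropyl on an aromatic carbon cannot be read (an at least 1.2-fold lower number from compound 1 to compound 4 (0.07 log units; that floor lies within the scatter)). In a physicochemical assay for solubility (a higher number here means a more soluble compound, a lower number a less soluble compound), compound 3 gives 17 ug/mL as its measured number. In the physicochemical assay compound 4 gives < 1 ug/mL as its entry, which is a limit of the assay and not a number. In the physicochemical assay 2-methoxyphenyl in place of 4-methoxypyridin-3-yl on a carbonyl carbon gives a large fall (an at least 17-fold lower number from compound 3 to compound 4 (1.23 log units; beyond the scatter)).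

From the compounds shown here alone, compound 4 stands at a limit on both read-outs, so the full size of each step into it stays open, as does any link between the two read-outs. Also open, going by these compounds, is where both read-outs would fall with a morpholine-bearing or carboxylic acid-bearing group in place of 2-methoxyphenyl on that carbonyl carbon.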